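Changes at the anilino ring of a shared core

This account rests on a few compounds, and the source may have more. Where it says the series, first, only, none or still open, it means among the compounds named here.

Measured compounds:
compound 1 `N#Cc1c(Nc2ccccc2F)nc(SCc2cn(Cc3ccccc3Cl)nn2)nc1-c1ccccc1` gives 8060 nM in a functional assay on MCF7 cells (Homo sapiens) for inhibition, read by MTT assay, with a stated time of 72 h; on this read-out lower numbers stand for stronger inhibition and higher numbers for weaker inhibition
compound 2 `N#Cc1c(Nc2ccc(F)cc2)nc(SCc2cn(Cc3ccccc3Cl)nn2)nc1-c1ccccc1` gives 19900 nM in this assay
compound 3 `Cc1ccccc1Nc1nc(SCc2cn(Cc3ccccc3Cl)nn2)nc(-c2ccccc2)c1C#N` gives 7950 nM in this assay

Compound 3 carries the lowest number of the three in this assay, though compound 1 sits within the scatter of it (a 1.0-fold lower number from compound 1 to compound 3 (0.01 log units; within the scatter)); only compound 2 is clearly apart (a 2.5-fold lower number from compound 2 to compound 3 (0.40 log units; beyond the scatter)). Compound 4 `N#Cc1c(Nc2ccccc2)nc(SCc2cn(Cc3ccccc3Cl)nn2)nc1-c1ccccc1` is not yet measured. It differs from compound 3 by hydrogen in place of methyl on an aromatic carbon.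

Among the compounds with values here, no measured step removes an ortho group outright. The nearest guide is the swap of fluoro for methyl at that carbon, which was flat (a 1.0-fold lower number from compound 1 to compound 3 (0.01 log units; within the scatter)), while moving the fluoro to the para position cost a modest amount (a 2.5-fold higher number from compound 1 to compound 2 (0.39 log units; beyond the scatter)). The ortho group itself therefore seems to matter little, and its removal is expected to give a step of a 1.3-fold higher number from compound 3 to compound 4 (0.10 log units; within the scatter), if anything a slightly higher number. Compound 4 is estimated at 10000 nM, within 4000 nM to 25000 nM in this assay.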

Compound 4, half-maximal inhibitory concentration: > 64000 nM
Compound 4: only a limit was reported; the forecaster's own chance of this, stated with the estimate: 5%; middle value at least 6.4-fold (0.80 log units) away from the limit.
By their numbers in this assay, from the lowest: compounds 3 and 1 (each within the scatter of the next); then compound 2. At a limit, above all of these: compound 4.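

Compound 4 reads > 64000 nM in this assay, and this is a limit of the assay, not a number. Removing the group differs sharply from exchanging it: an at least 8.0-fold higher number from compound 3 to compound 4 (0.90 log units; beyond the scatter) and an at least 7.9-fold higher number from compound 1 to compound 4 (0.89 log units; beyond the scatter), so methyl and fluoro on this ring carbon both go with far lower numbers than hydrogen, which the flat swap between those two groups could not show. The same holds for the ring with its fluoro placed elsewhere, an at least 3.2-fold higher number from compound 2 to compound 4 (0.50 log units; beyond the scatter), so anilino stands apart from all three substituted rings shown.

Going by these compounds, with only a limit for compound 4, the full size of these steps stays unknown. On these data alone, whether a chloro, a methoxy or an amine on the same ring carbon would also keep the lower numbers remains open.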